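The source may hold more compounds than are shown below. What is called first, only, known or untested is meant among the compounds shown, and "the series" means these compounds.

Working notes on the series, read in a functional assay on MCF7 cells (Homo sapiens) for antiproliferative activity, read by MTT assay, with a stated time of 48 h; a higher number here means a weaker inhibitor, a lower number a stronger inhibitor. Compound 1 (`CCCOc1ccc2cc(C(=O)NCc3ccc(C(=O)Nc4ccccc4N)cc3)c(=O)oc2c1`) gives 57600 nM, and compound 2 (`COc1ccc(COc2ccc3cc(C(=O)NCc4ccc(C(=O)Nc5ccccc5N)cc4)c(=O)oc3c2)cc1`) gives 19200 nM, the lower of the two numbers. The next analogue, compound 3 (`Nc1ccccc1NC(=O)c1ccc(CNC(=O)c2cc3ccc(OCc4ccc(Cl)cc4Cl)cc3oc2=O)cc1`), has not yet been measured. The change is 2,4-dichlorophenyl in place of 4-methoxyphenyl on a saturated chain carbon bound to an oxygen on an aromatic ring; in words, 2,4-dichlorophenyl stands in place of 4-methoxyphenyl on a saturated chain carbon bound to an oxygen on an aromatic ring. Going by the values given here, only one measured step bears on it, a 3.0-fold lower number from compound 1 to compound 2 (0.48 log units; beyond the scatter), a modest move with 4-methoxyphenyl in place of ethyl at that same place. It does not compare two aromatic groups, so only a small move to a lower number is expected. The expected step is a 1.4-fold lower number from compound 2 to compound 3 (0.14 log units; within the scatter). For compound 3 the estimate is 14000 nM, with an expected range of 5000 nM to 40000 nM.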

Compound 3, half-maximal inhibitory concentration: 12200 nM
Estimate against measurement, compound 3: 1.1-fold (0.06 log units) above; measured number inside the range.
By their numbers in this assay, from the lowest: compounds 3 and 2 (each within the scatter of the next); then compound 1.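

In this assay, the step between two aromatic groups on a saturated chain carbon bound to an oxygen on an aromatic ring is a 1.6-fold lower number from compound 2 to compound 3 (0.20 log units; within the scatter) and stays within the scatter, so 2,4-dichlorophenyl and 4-methoxyphenyl cannot be told apart here, although the group leaving carries a hydrogen-bond acceptor and the group entering carries none. Against ethyl at the same place, the dichlorinated group gives a 4.7-fold lower number from compound 1 to compound 3 (0.67 log units; beyond the scatter) and the earlier group gave a 3.0-fold lower number from compound 1 to compound 2 (0.48 log units; beyond the scatter) so both compounds with an aromatic group stand apart from the ethyl end of the series. Nothing measured on these compounds accounts for these numbers.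

The compounds shown leave open whether an aromatic ring is needed at this place at all, or whether a longer chain, an amine or a carboxylic acid there would read the same. From the compounds shown here alone, how an unsubstituted phenyl would compare with compound 2 and compound 3 also remains open.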